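A few compounds are considered here, and "the series" means these few. Any claim that something is new, unique, unknown or untested is made for them only; others in the source may bear on it.

In an ADME assay on MT4 cells (Homo sapiens) for cytotoxicity, read by MTT assay, with a stated time of 5 days (on this read-out higher numbers stand for lower toxicity in this test and lower numbers for higher toxicity in this test), compound 3, `CC(=O)Cn1cc(CNC(=O)c2cnc(Nc3ccc(C#N)cc3)cc2Oc2c(C)cc(C)cc2C)nn1`, gives 19400 nM, the lowest of the two plain numbers in this set. Compound 1, `Cc1cc(C)c(Oc2cc(Nc3ccc(C#N)cc3)ncc2C(=O)NCc2cn(Cc3cccc(Cl)c3)nn2)c(C)c1`, gives 187000 nM in this assay. Compound 2, `Cc1cc(C)c(Oc2cc(Nc3ccc(C#N)cc3)ncc2C(=O)NCc2cn(Cc3cccc(F)c3)nn2)c(C)c1`, reaches only the limit of >= 204000 nM in this assay, a limit of the assay rather than a number; this is the limit of >= 204000 nM in this assay, at which 1 of the 3 values shown sits.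

Compound 4, `Cc1cc(C)c(Oc2cc(Nc3ccc(C#N)cc3)ncc2C(=O)NCc2cn(Cc3cccc(C#N)c3)nn2)c(C)c1`, has not yet been measured in this assay. It differs from compound 3 by 3-cyanophenyl in place of acetyl on a saturated chain carbon bound to an aromatic nitrogen. The relevant steps run the opposite way: the change a 9.6-fold lower number from compound 1 to compound 3 (0.98 log units; beyond the scatter) and the change an at least 10-fold lower number from compound 2 to compound 3 (1.02 log units; beyond the scatter) both replaced an aromatic group with acetyl on that chain carbon and lowered the number. Restoring an aromatic group, here 3-cyanophenyl, is therefore expected to raise the number by a similar amount, and the expected step is a 9.8-fold higher number from compound 3 to compound 4 (0.99 log units; beyond the scatter). Compound 4 is estimated to give 190000 nM in this assay, with a likely range from 80000 nM to 400000 nM.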

Compound 4, half-maximal cytotoxic concentration: >= 129000 nM
Compound 4: a limit, no number; the forecaster's own chance of this, stated with the estimate: 45%; the middle value does not contradict the limit.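

In this assay, placing 3-cyanophenyl in place of acetyl on this chain carbon gives an at least 6.6-fold higher number from compound 3 to compound 4 (0.82 log units; beyond the scatter). The earlier compounds showed this kind of rise only with a chloro or fluoro group on the ring; now a nitrile on the ring also leaves the number far from that of compound 3, which is the only compound shown without the aromatic ring at this place. The steps from compound 1 and compound 2 to compound 4 cannot be read, because compound 4 ends at a limit and not at a number: the limit of >= 129000 nM in this assay, at which 1 of the 4 values shown sits.

On these data alone, it remains open whether the aromatic ring itself matters or only the loss of acetyl. An unsubstituted benzyl group, a plain propyl chain or a chain ending in an amine at this place would help separate these two readings.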